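A Second Carboxy Group on a Flat Series

The source may hold more compounds than are shown below. What is called first, only, known or untested is meant among the compounds shown, and "the series" means these compounds.

In a functional assay on MCF7 cells (Homo sapiens) for antiproliferative activity, read by MTT assay, with a stated time of 24 h (a higher number here means a weaker inhibitor, a lower number a stronger inhibitor), three compounds built on one shared core have been tested. Compound 1 `CCn1c(C(=O)N[C@H](CO)C(C)C)ccc1C(CC)(CC)c1ccc(OCS(=O)(=O)c2ccccc2)c(C)c1` gives 25500 nM and compound 2 `CCn1c(C(=O)NCC(=O)O)ccc1C(CC)(CC)c1ccc(OCS(=O)(=O)c2ccccc2)c(C)c1` gives 33100 nM while compound 3 `CCn1c(C(=O)N[C@H](C(=O)O)C(C)C)ccc1C(CC)(CC)c1ccc(OCS(=O)(=O)c2ccccc2)c(C)c1` gives 24500 nM as its half-maximal inhibitory concentration. These numbers lie within the scatter of one another, so compound 3 holds no separate rank among the three.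

Compound 4 `CCn1c(C(=O)N[C@@H](CC(=O)O)C(=O)O)ccc1C(CC)(CC)c1ccc(OCS(=O)(=O)c2ccccc2)c(C)c1` keeps the core of compound 3 and alters one group, with carboxymethyl in place of isopropyl on a saturated chain carbon bound to an amide-type nitrogen and a carbonyl carbon.

Within the data shown here, three measured steps bear on this change. Isopropyl in place of hydrogen at that same carbon gave a 1.4-fold lower number from compound 2 to compound 3 (0.13 log units; within the scatter) and is the closest guide. Carboxy in place of hydroxymethyl gave a 1.0-fold lower number from compound 1 to compound 3 (0.02 log units; within the scatter) and shows another swap that brought in a carboxy group. The wider change of carboxymethyl in place of 1-(hydroxymethyl)-2-methylpropyl gave a 1.3-fold higher number from compound 1 to compound 2 (0.11 log units; within the scatter) on the same scale. None of these steps leaves the scatter, so no clear direction can be drawn from them.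

The expected change is a 1.2-fold higher number from compound 3 to compound 4 (0.09 log units; within the scatter) and no shift beyond the scatter is expected in this assay. For compound 4 the estimated value is 30000 nM with an expected range from 16000 nM to 60000 nM in this series.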

Compound 4, half-maximal inhibitory concentration: > 50000 nM
Compound 4: a limit, no number (the forecaster's own chance of this, stated with the estimate: 15%); at least 1.6-fold (0.22 log units) between middle value and limit.
By their numbers in this assay, from the lowest: compounds 3, 1 and 2 (each within the scatter of the next). At a limit, above all of these: compound 4.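

In this assay compound 4 gives > 50000 nM, which is a limit and not a number, and it is the only compound shown that ends at a limit: the limit of > 50000 nM in this assay, at which 1 of the 4 values shown sits. On the saturated chain carbon bound to an amide-type nitrogen and a carbonyl carbon, carboxymethyl in place of isopropyl gives an at least 2.0-fold higher number from compound 3 to compound 4 (0.30 log units; that floor lies within the scatter), and carboxymethyl in place of hydrogen gives an at least 1.5-fold higher number from compound 2 to compound 4 (0.17 log units; that floor lies within the scatter). Among these compounds, the wider swap of 1,2-dicarboxyethyl in place of 1-(hydroxymethyl)-2-methylpropyl on the amide-type nitrogen gives an at least 1.9-fold higher number from compound 1 to compound 4 (0.29 log units; that floor lies within the scatter), so all three floors stay within the scatter, yet this position now holds the one compound with two carboxy groups and the one result without a number, something the earlier compounds did not show.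

On these data alone, how far compound 4 truly lies from the others stays open, since a limit gives no size for any of these steps. Also open, as far as these compounds go, is what a methyl ester of the carboxymethyl group, an aminomethyl group or a longer chain such as 2-carboxyethyl would give on the same carbon in this assay.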